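A few compounds are considered here, and "the series" means these few. Any claim that something is new, unique, unknown or untested is made for them only; others in the source may bear on it.

Measured so far in a functional assay on A-431 cells (Homo sapiens) for cytotoxicity, read by MTT assay, with a stated time of 72 h, tested at 100 uM; on this read-out higher numbers stand for more inhibition of growth at the one concentration tested and lower numbers for less inhibition of growth:

Compound 1 `N/C(=N\NC(=S)N1CCOCC1)c1ccccn1`: 84.6%
Compound 2 `N/C(=N\NC(=S)N1CCSCC1)c1ccccn1`: 80.8%

Compound 2 stands as the lower of the two numbers; its nearest neighbour is compound 1, and the step of a number 3.8 percentage points lower from compound 1 to compound 2 (within the scatter) lies within the scatter, so the two values are not told apart.

Compound 3 `N/C(=N\NC(=S)N1CCCCC1)c1ccccn1` has not been measured. It differs from compound 2 in one place: piperidin-1-yl in place of thiomorpholin-4-yl on a thiocarbonyl carbon. The ring that enters has no hydrogen-bond acceptor, where the ring that leaves has one.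

Within the data shown here, only one measured step bears on this change, the exchange of one six-membered saturated ring for another on the same thiocarbonyl carbon, a number 3.8 percentage points lower from compound 1 to compound 2 (within the scatter), and that step is within the scatter. On that basis no step beyond the scatter is expected in this assay from compound 2 to compound 3, in either direction; the change from compound 2 to compound 3 is expected to be a number 1.8 percentage points lower from compound 2 to compound 3 (within the scatter).

For compound 3 the estimate in this assay is 79%, with a range from 64% to 90%.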

Compound 3, percent growth inhibition at one concentration: 85.6%
Compound 3: middle estimate off by 6.6 percentage points, on the low side, within the range that was stated.
By their numbers in this assay, from the lowest: compounds 2, 1 and 3 (each within the scatter of the next).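

In this assay, the thiocarbonyl carbon now carries a third six-membered saturated ring without the read-out separating it from the other two: replacing thiomorpholin-4-yl with piperidin-1-yl gives a number 4.8 percentage points higher from compound 2 to compound 3 (within the scatter) and replacing morpholin-4-yl with piperidin-1-yl gives a number 1 percentage points higher from compound 1 to compound 3 (within the scatter) in the same assay. Until now, every ring at this place had held a second hetero atom, and compound 3 shows that a ring with only its nitrogen and no hydrogen-bond acceptor stays level with compound 1 and compound 2, so neither that second hetero atom nor the acceptor of thiomorpholin-4-yl is needed for growth inhibition at the one concentration tested. Nothing shown here gives a reason why the three rings read alike.

The compounds shown leave open whether this tolerance extends beyond six-membered saturated rings with no further substituent, for example to a pyrrolidin-1-yl ring, a piperazin-1-yl ring or an open-chain diethylamine on the same carbon. They also leave open whether the three rings would separate at lower concentrations, where a single-concentration read-out gives no information.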